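The source may hold more compounds than are shown below. What is called first, only, known or untested is meant among the compounds shown, and "the series" means these compounds.

Among the compounds with values here, compound 3 `C=CCc1ccc(OCc2cn(-c3cccc(C#N)c3)nn2)c(O)c1` gives 41.6% in a functional assay on MIA PaCa-2 cells (Homo sapiens) for inhibition, read by MTT assay, with a stated time of 72 h, tested at 50 uM (on this read-out higher numbers stand for more inhibition of growth at the one concentration tested and lower numbers for less inhibition of growth), the lowest of the three numbers so far. Compound 2 `C=CCc1ccc(OCc2cn(-c3cc(OC)c(OC)c(OC)c3)nn2)c(O)c1` gives 49.8%, which lies within the scatter of compound 3. Within the data shown here, compound 1 `C=CCc1ccc(OCc2cn(-c3ccccc3CO)nn2)c(O)c1` gives 52.1%, and the only one-place step recorded, a number 10.5 percentage points lower from compound 1 to compound 3 (beyond the scatter), is a modest fall. Compound 4 `C=CCc1ccc(OCc2cn(-c3ccc(Br)cc3)nn2)c(O)c1` differs from compound 3 in the group on an aromatic nitrogen: 4-bromophenyl in place of 3-cyanophenyl on an aromatic nitrogen. The step from compound 1 to compound 3 also swaps one substituted phenyl for another, but with different groups, so it gives no firm direction here, and all three measured values sit in a narrow band. The expected step is therefore a number 3.4 percentage points higher from compound 3 to compound 4 (within the scatter), not beyond the scatter. Compound 4 is estimated at 45%, with a range from 30% to 60%.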

Compound 4, percent growth inhibition at one concentration: 47.3%
For compound 4 the middle estimate is 2.3 percentage points below the measured one, within the range that was stated.
By their numbers in this assay, from the lowest: compounds 3, 4, 2 and 1 (each within the scatter of the next, the first and the last beyond it).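

In this assay, 4-bromophenyl on the aromatic nitrogen gives a number 5.7 percentage points higher from compound 3 to compound 4 (within the scatter) and a number 4.8 percentage points lower from compound 1 to compound 4 (within the scatter), both within the scatter. This position therefore takes a bromine-bearing phenyl without a separable change from either earlier aryl group, and compound 4 bridges the two ends of the gap that was beyond the scatter. Nothing available explains these steps.

Open, going by these compounds, is whether a phenyl carrying an amine or a carboxylic acid, or a longer alkyl chain in place of the phenyl, stays in this same narrow band.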